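Methyl for bromo on two different ketone cores

The source may hold more compounds than are shown below. What is called first, only, known or untested is meant among the compounds shown, and "the series" means these compounds.

Measured compounds:
Compound 1, `O=C1/C(=C/c2cccc(Br)c2)CCCc2ccccc21`: 10500 nM
Compound 2, `Cc1cccc(/C=C2\CCCc3ccccc3C2=O)c1`: 19900 nM
Compound 3, `O=C1CCCCC/C1=C\c1cccc(Br)c1`: 24100 nM

All three were tested in a functional assay on P388 cells (Mus musculus) for inhibition; a higher number here means a weaker inhibitor, a lower number a stronger inhibitor. Compound 1 and compound 2 share a core and differ only by methyl in place of bromo on an aromatic carbon; this gave a 1.9-fold higher number from compound 1 to compound 2 (0.28 log units; within the scatter). Compound 3 carries a different core, and the difference between the two cores is not broken down here. Compound 3 stands closest to compound 2 and furthest from compound 1, that gap lying beyond the scatter.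

Compound 4, `Cc1cccc(/C=C2\CCCCCC2=O)c1`, has not yet been measured. It differs from compound 3 by methyl in place of bromo on an aromatic carbon. This is the same kind of change as that from compound 1 to compound 2, though the surroundings differ: in compound 3 the ring carbon is meta to a group of 9 heavy atoms, whereas in compound 1 it is meta to a large group. Resting on the single earlier step of a 1.9-fold higher number from compound 1 to compound 2 (0.28 log units; within the scatter), the step from compound 3 to compound 4 is expected to be a 1.7-fold higher number from compound 3 to compound 4 (0.24 log units; within the scatter) in this assay. Compound 4 is therefore estimated at 42000 nM, with a range from 18000 nM to 100000 nM.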

Compound 4, half-maximal inhibitory concentration: 29800 nM
Compound 4: middle estimate off by 1.4-fold (0.15 log units), on the high side, within the range that was stated.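

In this assay, methyl in place of bromo on an aromatic carbon gave a 1.2-fold higher number from compound 3 to compound 4 (0.09 log units; within the scatter). Set beside the earlier step, the two results do not differ measurably: the same change on two cores in this assay, a 1.9-fold higher number (0.28 log units; within the scatter) from compound 1 to compound 2 and a 1.2-fold higher number (0.09 log units; within the scatter) from compound 3 to compound 4, 1.5-fold (0.19 log units) apart, within the scatter of two such steps. Among the compounds shown here, the change therefore reads alike on the core of compound 1 and the core of compound 3, but both steps lie within the scatter, so this shows only that the swap made no clear difference on either core, and two cores are too few to support a rule for the whole series.

The compounds shown carry only bromo or methyl at this place on the aromatic ring, which leaves open how a quite different group there, such as a methoxy group, an amine or a carboxylic acid, would read in this assay. From the compounds shown here alone, it also remains open whether methyl in place of bromo would stay within the scatter on any core other than these two.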